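Chloro to Methoxy on the Aryl Ring of Compound 1

The source may hold more compounds than are shown below. What is called first, only, known or untested is meant among the compounds shown, and "the series" means these compounds.

Compound 1 `O=C1NCCN(c2cccc(Cl)n2)N1` sits at the higher of the two numbers measured in an assay on RBL-1 cells for inhibition of Polyunsaturated fatty acid 5-lipoxygenase (Rattus norvegicus) (a higher number here means a weaker inhibitor, a lower number a stronger inhibitor), where compound 1 gives 5600 nM. Its nearest neighbour is compound 2 `CC1CN(c2cccc(Cl)n2)NC(=O)N1`, which in this assay gives 3500 nM; the move a 1.6-fold lower number from compound 1 to compound 2 (0.20 log units; within the scatter), methyl in place of hydrogen on a saturated ring carbon, stays within the scatter. Compound 3 `COc1cccc(N2CCNC(=O)N2)n1` differs from compound 1 in another place: methoxy in place of chloro on an aromatic carbon. Within the data shown here, no measured step touches this position of the shared core, and the single measured step, from compound 1 to compound 2, lies elsewhere and is within the scatter, so there is no basis for expecting a shift beyond the scatter in either direction. The author therefore expects compound 3 to give about 5000 nM in this assay, with a range from 1500 nM to 17000 nM, which means an expected step of a 1.1-fold lower number from compound 1 to compound 3 (0.05 log units; within the scatter).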

Compound 3, half-maximal inhibitory concentration: 9500 nM
Compound 3: the middle estimate sits 1.9-fold (0.28 log units) below what was measured, within the range that was stated.
By their numbers in this assay, from the lowest: compounds 2, 1 and 3 (each within the scatter of the next, the first and the last beyond it).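

Among these compounds, this is the first measured step at this position, on an aromatic carbon next to the ring nitrogen, and in this assay the exchange of chloro for methoxy gives a 1.7-fold higher number from compound 1 to compound 3 (0.23 log units; within the scatter). The shared core thus accepts methoxy here with a shift that cannot be told apart from the scatter, so this one change shows no measurable effect on the number at this position. Nothing measured bears on what lies behind this result.

With only chloro and methoxy shown at this position, it stays open whether an amine, a carboxylic acid or a longer chain such as butoxy there would move the number beyond the scatter. Also open, going by these compounds, is how methoxy here would behave together with the methyl on the saturated ring carbon of compound 2.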